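Moving Past the Limit: From Compound 2 to Compound 3

The compounds below may be only part of what the source reports. "The series", "measured", "known", "first", "only" and "open" are said of these compounds alone.

Compound 1 (`Cc1cc(C)cc(S(=O)(=O)c2c(C(=O)NC(C)C(=O)NCCn3c(C)cnc3[N+](=O)[O-])[nH]c3ccc(Cl)cc23)c1`): 16000 nM
Compound 2 (`COc1cccc(F)c1CNC(=O)c1[nH]c2ccc(Cl)cc2c1S(=O)(=O)c1cc(C)cc(C)c1`): > 49900 nM (a limit)

In an ADME assay on MT4 cells (Homo sapiens) for cytotoxicity, read by MTT assay (a lower number here means that less compound is tolerated, a higher number that more compound is tolerated), compound 1 gives 16000 nM as a measured number. Compound 2 gives > 49900 nM as a limit of the assay and not a number. Compound 2 thus stands at the limit of > 49900 nM in this assay, at which 1 of the 2 values shown sits, and has no measured number of its own.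

Compound 3 (`Cc1cc(C)cc(S(=O)(=O)c2c(C(=O)NC(c3ccc(Cl)cc3)C3CC3)[nH]c3ccc(Cl)cc23)c1`) keeps the shared core of compound 2 and differs only on the amide-type nitrogen. The change is this: a group of 11 heavy atoms (10 carbon, 1 chlorine; one three-membered non-aromatic ring of carbon only, one six-membered aromatic ring of carbon only) in place of a group of 10 heavy atoms (8 carbon, 1 oxygen, 1 fluorine; one six-membered aromatic ring of carbon only), on an amide-type nitrogen. No measured step sizes such an exchange, and the starting point is a limit. For the measured compounds named here, the expectation therefore leans on compound 1, whose 16000 nM is the one measured number for this core. Compound 3 may well end at the limit too, but a measurable number is thought somewhat more likely. The expected change in this assay is an at least 2.4-fold lower number from compound 2 to compound 3 (0.39 log units; beyond the scatter) as an estimated downward step of moderate size. For compound 3 the estimate is 20000 nM, with an expected range from 6000 nM to 50000 nM in this measurement.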

Compound 3, half-maximal cytotoxic concentration: > 47300 nM
Compound 3 ended at the assay's limit (the forecaster's own chance of this, stated with the estimate: 35%); middle value at least 2.3-fold (0.37 log units) away from the limit.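

In this assay compound 3 gives > 47300 nM, a limit of the assay and not a number. Compound 2 gives > 49900 nM, also a limit, so no step can be read between compound 2 and compound 3. The compounds shown leave open where either half-maximal cytotoxic concentration lies, and whether the exchange on the amide-type nitrogen changes it.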